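The compounds below may be only part of what the source reports. "The series", "measured", "known", "first", "only" and "open" are said of these compounds alone.

Measured compounds:
Compound 1 `CCCCC[Se]c1nc(NCc2ccc(SC)cc2)c2ccccc2n1` gives 34700 nM in a functional assay on MCF7 cells (Homo sapiens) for cytotoxicity, read by MTT assay, with a stated time of 72 h; a higher number here means a weaker inhibitor of growth, a lower number a stronger inhibitor of growth.
Compound 2 `CCCCC[Se]c1nc(NCc2ccccc2)c2ccccc2n1` gives 50 nM in this assay.
Compound 3 `COc1ccc(CNc2nc(SC)nc3ccccc23)cc1` gives 30900 nM in this assay.

Among these three, compound 1 carries the highest number in this assay; compound 3 sits within the scatter of it, while compound 2 lies far away, as the step of a 690-fold lower number from compound 1 to compound 2 (2.84 log units; beyond the scatter) shows for the removal of the methylsulfanyl group from the benzyl ring.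

Compound 4 `CSc1ccc(CNc2nc([Se]C)nc3ccccc23)cc1` is not yet measured. It differs from compound 1 by hydrogen in place of butyl on a saturated chain carbon bound to a selenium atom; the methylsulfanylbenzyl part of compound 1 is kept. Within the data shown here, none of the measured steps alters the chain on the selenium atom, so there is no direct measured step bearing on this change. Among the measured compounds shown here, the only indirect pointer is compound 3, which carries a short chain on the sulfur atom at the corresponding position and gives a number within the scatter of compound 1 in this assay, though its benzyl ring carries methoxy rather than methylsulfanyl, so the two are not a clean pair. On this basis a step of no clear size beyond the scatter is expected, a 1.2-fold lower number from compound 1 to compound 4 (0.06 log units; within the scatter). Compound 4 is therefore estimated at 30000 nM in this assay, with a range from 8000 nM to 100000 nM.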

Compound 4, concentration for 50% growth inhibition: 54100 nM
Estimate against measurement, compound 4: 1.8-fold (0.26 log units) below, within the range that was stated.
By their numbers in this assay, from the lowest: compound 2; then compounds 3, 1 and 4 (each within the scatter of the next).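

In this assay, among these compounds, the change from pentyl to methyl on the selenium atom, with the methylsulfanylbenzyl part kept, gives a 1.6-fold higher number from compound 1 to compound 4 (0.19 log units; within the scatter) and is the first direct reading of this position. It shows that, in this pair, shortening the chain on the selenium atom moves the number by no more than the scatter, so both compounds stay in the same weak range. Among the compounds shown here, the large change seen so far, a 690-fold lower number from compound 1 to compound 2 (2.84 log units; beyond the scatter) for the loss of methylsulfanyl with the pentyl chain in place, therefore remains the only step beyond the scatter, and nothing given here accounts for either reading.

On these data alone, what remains open is whether the chain on the selenium atom would matter just as little in the far stronger setting of compound 2, where the benzyl ring carries only hydrogen, since that compound has no partner with a methyl group on the selenium atom. Also open, as far as these compounds go, is how this position would respond to something other than a plain short or medium chain, such as a longer chain of decyl or one ending in a carboxylic acid or an amine.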